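Replacing the trichlorophenyl group in compound 2

A few compounds are considered here, and "the series" means these few. Any claim that something is new, unique, unknown or untested is made for them only; others in the source may bear on it.

Compound 1 `O=C(/C(=C\c1ccc(O)cc1)SCc1ccc(Cl)cc1)c1ccc(Br)cc1` gives 10000 nM
Compound 2 `O=C(/C(=C\c1cc(Cl)cc(Cl)c1Cl)SCc1ccc(Cl)cc1)c1ccc(Br)cc1` gives 1000 nM

In a functional assay on DU-145 cells (Homo sapiens) for inhibition, read by trypan blue exclusion, with a stated time of 96 h (on this read-out higher numbers stand for weaker inhibition of growth and lower numbers for stronger inhibition of growth), compound 2 sits at 1000 nM and holds the lower of the two numbers. The change to compound 3 `CN(C)c1ccc(/C=C(/SCc2ccc(Cl)cc2)C(=O)c2ccc(Br)cc2)cc1` is 4-(dimethylamino)phenyl in place of 2,3,5-trichlorophenyl on a double-bonded chain carbon bound to a double-bonded chain carbon and touches nothing else. For the measured compounds named here, the one measured step that bears on it is a 10-fold lower number from compound 1 to compound 2 (1.00 log units; beyond the scatter) and it put 2,3,5-trichlorophenyl in place of 4-hydroxyphenyl. Compound 3 gives up that same 2,3,5-trichlorophenyl, so a move back to a higher number is expected, probably a smaller one, though a single step is thin evidence. The estimated move in this assay is a 3.0-fold higher number from compound 2 to compound 3 (0.48 log units; beyond the scatter) and remains uncertain. For compound 3 the estimated value is 3000 nM with an expected range from 700 nM to 12000 nM in this read-out.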

Compound 3, concentration for 50% growth inhibition: 10000 nM
Beside the measured number, compound 3's estimate is 3.3-fold (0.52 log units) below it; the measured number falls inside the stated range.
By their numbers in this assay, from the lowest: compound 2; then compounds 1 and 3 (each within the scatter of the next).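

Putting in 4-(dimethylamino)phenyl gives a 10-fold higher number from compound 2 to compound 3 (1.00 log units; beyond the scatter) in this assay, so the step back is as large as the step that brought in 2,3,5-trichlorophenyl, not smaller. Dimethylamino in place of hydroxy on an aromatic carbon gives no change at the digits printed from compound 1 to compound 3 (within the scatter), so these two groups cannot be told apart here, and only 2,3,5-trichlorophenyl stands out. Nothing available explains this difference. Still open, as far as these compounds go, is whether a plain phenyl, a phenyl with a single chlorine or a pyridine ring would keep the lower number of compound 2.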